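Swapping the Aryl Group on the Urea Nitrogen

A few compounds are considered here, and "the series" means these few. Any claim that something is new, unique, unknown or untested is made for them only; others in the source may bear on it.

Compound 2 `COc1nc(C)cc(SC)c1NC(=O)N(Cc1ccc(Oc2ccc(F)cc2)cc1)C1CCCCCC1` gives 29 nM in an assay for inhibition of acyl-CoA:cholesterol acyltransferase (Oryctolagus cuniculus), using microsomes (a higher number here means a weaker inhibitor, a lower number a stronger inhibitor), and compound 1 `CSc1nc(C)nc(SC)c1NC(=O)N(Cc1ccc(Oc2ccc(F)cc2)cc1)C1CCCCCC1` gives 56 nM in this assay, the two numbers lying within the scatter of one another, as the change a 1.9-fold lower number from compound 1 to compound 2 (0.29 log units; within the scatter) shows. Compound 3 `Cc1cc(Cl)c(NC(=O)N(Cc2ccc(Oc3ccc(F)cc3)cc2)C2CCCCCC2)c(Cl)n1` differs from compound 2 by a group of 9 heavy atoms (6 carbon, 1 nitrogen, 2 chlorine; one six-membered aromatic ring with 1 hetero atom) in place of a group of 11 heavy atoms (8 carbon, 1 nitrogen, 1 oxygen, 1 sulfur; one six-membered aromatic ring with 1 hetero atom), on an amide-type nitrogen. Going by the values given here, the single measured step also exchanged a group on that amide-type nitrogen and stayed within the scatter, so no step beyond the scatter is expected now either; the move is estimated as a 1.2-fold higher number from compound 2 to compound 3 (0.08 log units; within the scatter). Compound 3 is therefore expected to give about 35 nM, between 10 nM and 120 nM.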

Compound 3, half-maximal inhibitory concentration: 14 nM
Compound 3: middle estimate off by 2.5-fold (0.40 log units), on the high side, within the range that was stated.
By their numbers in this assay, from the lowest: compound 3; then compounds 2 and 1 (each within the scatter of the next).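

Going by these compounds alone, with a 2.1-fold lower number from compound 2 to compound 3 (0.32 log units; beyond the scatter) and a 4.0-fold lower number from compound 1 to compound 3 (0.60 log units; beyond the scatter) in this assay, an exchange of the group on the amide-type nitrogen passes the scatter, which the single earlier step did not do. The position therefore responds to this choice of group, and the entering group with 2 chlorine atoms gives the lowest number of the three compounds. Nothing shown here accounts for the direction of these steps. The compounds shown leave open whether each chlorine contributes on its own, since the two appear only together. From the compounds shown here alone, how bromine or trifluoromethyl in their place would read also remains open.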